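This account rests on a few compounds, and the source may have more. Where it says the series, first, only, none or still open, it means among the compounds named here.

Within the data shown here, in an ADME assay on HEK-293T cells (Homo sapiens) for cytotoxicity, read by luminescence, with a stated time of 24 h (a higher number here means that more compound is tolerated, a lower number that less compound is tolerated), compound 2 `CCCNC(=O)C1CCN(C(=O)c2cc3sccc3n2Cc2ccc(OC)cc2)CC1` gives 18800 nM, the only actual number so far. Compound 1 `COc1ccc(Cn2c(C(=O)N3CCC(C(=O)NCc4cccc(Br)c4)CC3)cc3sccc32)cc1` gives > 100000 nM, which is a limit. Compound 3 `CCCNC(=O)C1CCN(C(=O)c2cc3sc(-c4ccccc4)cc3n2Cc2ccc(OC)cc2)CC1` gives > 100000 nM, also a limit. Compound 4 `CCCNCc1c(C(=O)N2CCC(C(=O)NCCC)CC2)n(Cc2ccc(OC)cc2)c2ccsc12` differs from compound 2 by (propylamino)methyl in place of hydrogen on an aromatic carbon. The closest measured change is phenyl in place of hydrogen on an aromatic carbon, an at least 5.3-fold higher number from compound 2 to compound 3 (0.72 log units; beyond the scatter), although the carbon and the group both differ. The change in the amide substituent, an at least 5.3-fold lower number from compound 1 to compound 2 (0.72 log units; beyond the scatter), bears on it only loosely. As far as these compounds go, both steps reach (the limit of > 100000 nM in this assay, at which 2 of the 3 values shown sit), so their full sizes are unknown. The expected step is a 1.5-fold higher number from compound 2 to compound 4 (0.17 log units; within the scatter), small, upward and not beyond the scatter. For compound 4, the estimated value is 28000 nM, with an expected range of 9000 nM to 90000 nM.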

Compound 4, half-maximal cytotoxic concentration: > 100000 nM
Compound 4 was reported as a limit; the forecaster's own chance of this, stated with the estimate: 25%; middle value at least 3.5-fold (0.55 log units) from the limit.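

Putting (propylamino)methyl on this aromatic carbon gives an at least 5.3-fold higher number from compound 2 to compound 4 (0.72 log units; beyond the scatter). A group with no ring therefore raises the number from compound 2, as the phenyl of compound 3 does on a different carbon. The value of compound 4 is a limit and the full size of the step is unknown: the limit of > 100000 nM in this assay, at which 3 of the 4 values shown sit.

Open, as far as these compounds go, is whether a plain pentyl chain, without the nitrogen, or a smaller aminomethyl on this carbon would give the same step. With compound 1, compound 3 and compound 4 all at the limit, these three cannot be ranked.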